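Swapping hydroxy for methoxy at high clearance

The source may report more compounds than this note shows. Statements on the series, on what has been measured and on what is new or still open speak of the compounds shown alone.

Values from an ADME assay on microsomes (Homo sapiens) for metabolic stability (on this read-out lower numbers stand for slow clearance and higher numbers for fast clearance), follow.

- compound 1 `CNC(=O)[C@@H]1CCCN1S(=O)(=O)c1ccc(Cl)c(COc2cccc3c(C(F)(F)F)cc(C)nc23)c1Cl`: 250 mL/min/kg
- compound 2 `Cc1cc(C(F)(F)F)c2cccc(OCc3c(Cl)ccc(S(=O)(=O)N4CCC[C@H]4CO)c3Cl)c2n1`: 250 mL/min/kg

Compound 2 stands level with compound 1 on these numbers, so the two cannot be told apart in this assay. The next structure, compound 3 `COC[C@@H]1CCCN1S(=O)(=O)c1ccc(Cl)c(COc2cccc3c(C(F)(F)F)cc(C)nc23)c1Cl`, differs from compound 2 in one place: methyl in place of hydrogen on an oxygen on a saturated carbon, which turns hydroxymethyl into methoxymethyl (methyl in place of hydrogen on an oxygen on a saturated carbon). Among the compounds with values here, only one measured step bears on this change, the swap of methylcarbamoyl for hydroxymethyl, and it stayed within the scatter: no change at the digits printed from compound 1 to compound 2 (within the scatter). Within the data shown here, that single step is thin evidence, and no measured compound carries this exact change. The expected size of the change is therefore none beyond the scatter, with no preferred direction: no change at the digits printed from compound 2 to compound 3 (within the scatter). The estimated clearance of compound 3 is 250 mL/min/kg, with an expected range from 130 mL/min/kg to 420 mL/min/kg.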

Compound 3, clearance: 450 mL/min/kg
The estimate for compound 3 lay 1.8-fold (0.26 log units) below the measured number, and the stated range ends below it.
By their numbers in this assay, from the lowest: compounds 1, 2 and 3 (each within the scatter of the next).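

On the saturated ring carbon, putting methyl on the oxygen of hydroxymethyl gives a 1.8-fold higher number from compound 2 to compound 3 (0.26 log units; within the scatter) in this assay and so does not separate the methoxy compound from the hydroxy compound. Replacing methylcarbamoyl with methoxymethyl gives a 1.8-fold higher number from compound 1 to compound 3 (0.26 log units; within the scatter) and so the three groups seen at this carbon, methylcarbamoyl, hydroxymethyl and methoxymethyl, all lie within the scatter of one another, which means that neither the free hydroxy hydrogen nor its methyl cap has a readable effect on these numbers. No measurement here offers an explanation for this result.

Still open, going by these compounds, is whether a carboxylic acid, an amine or a longer ether chain such as ethoxymethyl on this carbon would move clearance beyond the scatter. Also open, on these data alone, is whether any change at this carbon alone can do so, or whether the shared core must change too.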